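Moving a methoxy group on the aryl ring of a pyrrolopyridinone

The source may report more compounds than this note shows. Statements on the series, on what has been measured and on what is new or still open speak of the compounds shown alone.

In a functional assay on MV4-11 cells (Homo sapiens) for antiproliferative activity, read by CCK-8 assay, with a stated time of 72 h (a higher number here means a weaker inhibitor, a lower number a stronger inhibitor), compound 1 `COc1cccc(-c2cn(C)c(=O)c3[nH]c(C(=O)NCc4ccc(C(=O)Nc5ccccc5N)cc4)cc23)c1` gives 250 nM. Among the three compounds measured it stands with the second highest number: compound 3 `O=C(CCCCCCC(=O)Nc1cnc(N(c2ccccc2)c2ccccc2)nc1)NO` gives 890 nM, a higher number beyond the scatter, while compound 2 `Cn1cc(-c2ccccc2Oc2ccccc2)c2cc(C(=O)NCCCCCC(=O)Nc3ccccc3N)[nH]c2c1=O` gives 70 nM, a lower number beyond the scatter. Within the data shown here, compounds 2 and 3 share neither the core of compound 1 nor its linker, so they set no step that bears directly on the change at hand.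

Compound 4 `COc1ccc(-c2cn(C)c(=O)c3[nH]c(C(=O)NCc4ccc(C(=O)Nc5ccccc5N)cc4)cc23)cc1` has the same atoms as compound 1 joined differently: 4-methoxyphenyl in place of 3-methoxyphenyl on an aromatic carbon. Nothing else in the molecule moves.

Among the measured compounds shown here, no measured pair shows what this repositioning of the methoxy group does in this assay. With the rest of the molecule held the same, and only the position of one group on the pendant aromatic ring altered, he expects the step from compound 1 to compound 4 to be small, most likely within the scatter of repeated measurement, with no confident direction. In this assay compound 4 is therefore estimated at 250 nM, with a range from 80 nM to 800 nM; the step of no change at the digits printed from compound 1 to compound 4 (within the scatter) is expected to be modest at most.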

Compound 4, half-maximal inhibitory concentration: 320 nM
Beside the measured number, compound 4's estimate is 1.3-fold (0.11 log units) below it; measured number inside the range.
By their numbers in this assay, from the lowest: compound 2; then compounds 1 and 4 (each within the scatter of the next); then compound 3.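

In this assay, among these compounds, moving the methoxy group around the pendant ring gives a 1.3-fold higher number from compound 1 to compound 4 (0.11 log units; within the scatter), so this is the first comparison in the set that isolates a single change, and the 3-methoxyphenyl and 4-methoxyphenyl groups cannot be told apart at this aromatic carbon. For this one pair, the position of the methoxy group on the pendant ring therefore has no effect that can be separated from the scatter of repeated measurements, although the pair alone cannot show whether the same would hold for any other group on that ring. Nothing available here offers an explanation for this result, and no independent measurement bears on it.

As far as these compounds go, what remains open is whether the methoxy group contributes anything at all, a question that a plain phenyl ring at the same aromatic carbon, or a ring bearing a hydroxyl group, a fluorine atom or a dimethylamino group, could begin to answer. From the compounds shown here alone, it is also open whether compound 1 and compound 4 would stay this close in a different cell line or with a longer chain in place of the linker of the shared core.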